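The compounds below may be only part of what the source reports. "The series", "measured", "known", "first", "only" and "open" are said of these compounds alone.

Measured so far:
compound 1 `CN(C)CCCCN(C(=O)O)c1ccc(Cn2nc(-c3ccc(F)cc3)c3ccccc3c2=O)cc1`: 19000 nM
compound 2 `CN(C)CCCCOC(=O)Nc1ccc(Cn2nc(-c3cnn(C)c3)c3ccccc3c2=O)cc1`: 55900 nM

Both compounds were tested in an ADME assay on Huh-7 cells (Homo sapiens) for cytotoxicity, read by MTT assay, with a stated time of 48 h; a higher number here means that more compound is tolerated, a lower number that less compound is tolerated. Compound 2 stands at the higher of the two numbers; compound 1 gives the lower number, and the gap between them lies beyond the usual scatter. The two compounds differ in more than one place, so their values show only where each stands, not what any single change does.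

Compound 3 `CN(C)CCCCOC(=O)Nc1ccc(Cn2nc(-c3cccc(C(F)(F)F)c3)c3ccccc3c2=O)cc1` has not yet been measured. It differs from compound 2 in one place: 3-(trifluoromethyl)phenyl in place of 1-methyl-1H-pyrazol-4-yl on an aromatic carbon. Among the measured compounds shown here, no step between measured compounds isolates this change. Still, compound 1, which also carries a six-membered aromatic ring of carbon only at that place, gives 19000 nM, and on that basis a modest step downward from compound 2 is expected, a 1.9-fold lower number from compound 2 to compound 3 (0.27 log units; within the scatter). Compound 3 is therefore estimated at 30000 nM, within a range of 12000 nM to 70000 nM.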

Compound 3, half-maximal cytotoxic concentration: 11600 nM
Beside the measured number, compound 3's estimate is 2.6-fold (0.41 log units) above it, outside the stated range (below it).
By their numbers in this assay, from the lowest: compounds 3 and 1 (each within the scatter of the next); then compound 2.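

In this assay, among the compounds shown here, a 4.8-fold lower number from compound 2 to compound 3 (0.68 log units; beyond the scatter) comes from replacing 1-methyl-1H-pyrazol-4-yl with 3-(trifluoromethyl)phenyl, the first single-place comparison to show that the group on this aromatic carbon affects how much compound the cells tolerate. The swap changes several things at once: a five-membered aromatic ring with 2 hetero atoms and 2 hydrogen-bond acceptors gives way to a larger six-membered ring of carbon only, carrying trifluoromethyl, with no acceptors, so this one step cannot separate their contributions. No measurement at hand explains the difference.

From the compounds shown here alone, it remains open whether a plain phenyl or a pyridine ring at this place would stand nearer compound 2 or compound 3. Also open, going by these compounds, is whether the step would hold with a longer chain ending in the dimethylamino group.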